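From sulfonyl to sulfanyl in a growth inhibition test

The source may report more compounds than this note shows. Statements on the series, on what has been measured and on what is new or still open speak of the compounds shown alone.

- Compound 1 `O=C(/C(=C\c1c[nH]c2ccc(Br)cc12)SCc1ccc(Cl)cc1Cl)c1ccc(Cl)cc1`: 10000 nM
- Compound 2 `Cc1ccc(S(=O)(=O)/C(=C/c2c(O)cc(O)cc2O)C(=O)c2ccc(Cl)cc2)cc1`: > 100000 nM

Both compounds were tested in a functional assay on DU-145 cells (Homo sapiens) for inhibition, read by trypan blue exclusion, with a stated time of 96 h; a lower number here means a stronger inhibitor of growth, a higher number a weaker inhibitor of growth. Compound 2 stands at > 100000 nM, which is a limit of the assay and not a number.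

Compound 3 `O=C(/C(=C\c1c(O)cc(O)cc1O)SCc1ccc(Cl)cc1Cl)c1ccc(Cl)cc1` carries (2,4-dichlorobenzyl)sulfanyl in place of (4-methylphenyl)sulfonyl on a double-bonded chain carbon bound to a carbonyl carbon and a double-bonded chain carbon.

For the measured compounds named here, compound 1 carries the same (2,4-dichlorobenzyl)sulfanyl and gives 10000 nM, although no measured pair isolates this change. On that reading, an expected step towards stronger inhibition is an at least 12-fold lower number from compound 2 to compound 3 (1.09 log units; beyond the scatter). Compound 3 is estimated at 8000 nM, with an expected range from 1500 nM to 50000 nM.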

Compound 3, concentration for 50% growth inhibition: 25000 nM
Estimate against measurement, compound 3: 3.1-fold (0.49 log units) below, and the stated range covers the measured number.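

For the compounds shown here, putting (2,4-dichlorobenzyl)sulfanyl in place of (4-methylphenyl)sulfonyl gives an at least 4.0-fold lower number from compound 2 to compound 3 (0.60 log units; beyond the scatter) in this assay, the first measured pair to isolate this change. That step is only a minimum, since compound 2 stands at a limit of the assay: the limit of > 100000 nM in this assay, at which 1 of the 3 values shown sits. With the sulfanyl group held constant, 2,4,6-trihydroxyphenyl in place of 5-bromo-1H-indol-3-yl gives a 2.5-fold higher number from compound 1 to compound 3 (0.40 log units; beyond the scatter).

Going by these compounds, the swap changes the sulfur's oxidation state and its attached group together, so the contribution of each stays open. A plain benzylsulfanyl group or a (4-methylphenyl)sulfanyl group would separate them.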